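Trimming One Methoxy from Compound 1

The source may hold more compounds than are shown below. What is called first, only, known or untested is meant among the compounds shown, and "the series" means these compounds.

Compound 1 `COc1ccc(C(=O)NNC(=O)c2ccc3[nH]c(-c4ccc([N+](=O)[O-])o4)nc3c2)cc1OC` carries the lowest number of the three compounds measured in a functional assay on HT-29 cells (Homo sapiens) for inhibition, read by sulforhodamine B assay, with a stated time of 48 h (a lower number here means a stronger inhibitor of growth, a higher number a weaker inhibitor of growth), where compound 1 gives 15.6 ug/mL. Compound 2 `COc1cccc(C(=O)NNC(=O)c2ccc3[nH]c(-c4ccc([N+](=O)[O-])s4)nc3c2)c1` gives 31.3 ug/mL and compound 3 `COc1cc(C(=O)NNC(=O)c2ccc3[nH]c(-c4ccc([N+](=O)[O-])o4)nc3c2)cc(OC)c1OC` gives 31.3 ug/mL; the step from the first to the third of these is a 2.0-fold higher number from compound 1 to compound 3 (0.30 log units; within the scatter). Compound 4 `COc1cccc(C(=O)NNC(=O)c2ccc3[nH]c(-c4ccc([N+](=O)[O-])o4)nc3c2)c1` differs from compound 1 by hydrogen in place of methoxy on an aromatic carbon. Among the compounds with values here, the only measured step that alters a methoxy on this ring is a 2.0-fold higher number from compound 1 to compound 3 (0.30 log units; within the scatter), and it stayed inside the scatter, so removing one is not expected to carry the number beyond the scatter either; compound 2 and compound 1 also sit within the scatter of each other. Compound 4 is therefore expected to give 22 ug/mL, between 10 ug/mL and 45 ug/mL, a step of a 1.4-fold higher number from compound 1 to compound 4 (0.15 log units; within the scatter) that is estimated to be small.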

Compound 4, concentration for 50% growth inhibition: 31.3 ug/mL
Beside the measured number, compound 4's estimate is 1.4-fold (0.15 log units) below it, and the stated range covers the measured number.
By their numbers in this assay, from the lowest: compounds 1, 2, 3 and 4 (each within the scatter of the next).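

With hydrogen in place of methoxy on this carbon, para to a large group, a 2.0-fold higher number from compound 1 to compound 4 (0.30 log units; within the scatter) in this assay stays inside the scatter, so the 3,4-dimethoxyphenyl to 3-methoxyphenyl change does not separate the two compounds, just as the added methoxy in a 2.0-fold higher number from compound 1 to compound 3 (0.30 log units; within the scatter) did not. The new furan compound also gives no change at the digits printed from compound 2 to compound 4 (within the scatter) against its thiophene partner, so 5-nitrofuran-2-yl and 5-nitrothiophen-2-yl are not told apart here. Going by these compounds, whether an amine or a carboxylic acid on this carbon would move the number beyond the scatter remains open. No evidence given here accounts for these results.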